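This account rests on a few compounds, and the source may have more. Where it says the series, first, only, none or still open, it means among the compounds named here.

Measured so far in an in vitro assay on BTI-TN-5B1-4 cells for inhibition of Amine oxidase [flavin-containing] A (Homo sapiens), tested at 100 uM; on this read-out higher numbers stand for more inhibition at the one concentration tested (going by the name of the read-out) and lower numbers for less inhibition:
compound 1 `Cc1ccc2c(=O)cc(-c3ccc(F)cc3)oc2c1` — "not active" (no number reported)
compound 2 `Cc1ccc(-c2cc(=O)c3ccc(C)cc3o2)cc1` — 40%
compound 3 `COc1ccc(-c2cc(=O)c3ccc(C)cc3o2)cc1` — 40%

Compound 1 stands without a number: in this assay compound 1 is reported as "not active" (no number reported), while compound 2 and compound 3 each give a figure near the middle of the scale. Compound 4 `COc1ccc2c(=O)cc(-c3ccc(F)cc3)oc2c1` is the untested analogue; it differs from compound 1 in one place: methoxy in place of methyl on an aromatic carbon. Within the data shown here, the only measured step with the same exchange of groups is no change at the digits printed from compound 2 to compound 3 (within the scatter), so that exchange, where it has been tried, moved nothing beyond the scatter. On that basis compound 4 is expected to stay close to where compound 1 stands, with no step beyond the scatter in this assay. The estimate for compound 4 is 10%, ranging from 0% to 35%.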

Compound 4, a percentage reported as inhibition, at one concentration (the size of the read-out at that concentration, not a potency): "not active" (no number reported)
Compound 4: no number reported; the estimate stays without a comparison.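

In this assay, among these compounds, compound 1 gives "not active" (no number reported) and compound 4 gives "not active" (no number reported) as well, so no step between these two compounds can be read. The compounds shown leave open whether methoxy in place of methyl changes inhibition on the core of compound 1. No further data bear on this result.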